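Compound 3: a basic side chain replaces a hydroxyethoxy

The compounds below may be only part of what the source reports. "The series", "measured", "known", "first", "only" and "open" are said of these compounds alone.

Compound 1 `CCCCCOC(=O)N1CCN(C(=O)[C@H](CCC(=O)O)NC(=O)c2cc(N3CCC(C(=O)NCC)CC3)nc(-c3ccccc3)n2)CC1`: > 80%
Compound 2 `CCCCCOC(=O)N1CCN(C(=O)[C@H](CCC(=O)O)NC(=O)c2cc(N3CCC(OCCO)CC3)nc(-c3ccccc3)n2)CC1`: > 80%

Both compounds were tested in an ADME assay on microsomes from liver (Homo sapiens) for metabolic stability; on this read-out higher numbers stand for a more stable compound and lower numbers for a less stable compound. In this assay compound 1 gives > 80%, which is a limit of the assay rather than a number. Compound 2 gives > 80%, again a limit and not a number. For the measured compounds named here, the one measured step, a step that the two limits leave unreadable from compound 1 to compound 2, therefore cannot be read in size or direction. The pair sits at the limit of > 80% in this assay, at which 2 of the 2 values shown sit. Compound 2 thus stands at the upper edge of what this assay reports, with no measured value beyond it.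

Compound 3 `CCCCCOC(=O)N1CCN(C(=O)[C@H](CCC(=O)O)NC(=O)c2cc(N3CCC(CNC)CC3)nc(-c3ccccc3)n2)CC1` has not yet been measured. It differs from compound 2 in one place: (methylamino)methyl in place of 2-hydroxyethoxy on a saturated ring carbon. Going by the values given here, no measured step shows what a change of this kind does here, since the only step available is unreadable. With compound 2 at the limit and nothing in the data pointing downward, compound 3 is expected to remain near that limit. The expected step is a step that the limit leaves unreadable from compound 2 to compound 3. The estimate for compound 3 is 85%, within a range from 65% to 100%.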

Compound 3, percent of the compound remaining: > 80%
Compound 3: a limit, no number; the forecaster's own chance of this, stated with the estimate: 70%; the middle value lies beyond the limit too.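

In this assay compound 3 gives > 80%, which is a limit of the assay and not a number. The steps linking compound 1, compound 2 and compound 3 therefore cannot be read in size or direction: the limit of > 80% in this assay, at which 3 of the 3 values shown sit. The compounds shown leave open how the three differ in stability, and whether any of these groups on the saturated ring carbon would give a readable number.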